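Hydroxy in place of amino: compound 1 to compound 4

The compounds below may be only part of what the source reports. "The series", "measured", "known", "first", "only" and "open" are said of these compounds alone.

In a functional assay on MONO-MAC-6 cells (Homo sapiens) for cytotoxicity, read by MTT assay, with a stated time of 24 h (on this read-out lower numbers stand for stronger inhibition and higher numbers for weaker inhibition), compound 1 (`C/C(=N\OCC(=O)N[C@H](C(=O)N[C@@H](CCCCN)C(=O)N1CCC[C@H]1C(=O)N[C@@H](CCCCN)C(=O)NCC(N)=O)[C@@H](C)O)c1ccc(NC(=O)c2cc(Br)ccc2O)cc1`) gives > 200000 nM as a limit of the assay and not a number. Compound 2 (`O=C(Nc1ccc(C(F)(F)F)cc1)c1cc(Cl)ccc1O`) gives 2200 nM and compound 3 (`O=C(Nc1ccc(Cl)c(Cl)c1)c1cc(Br)ccc1O`) gives 1400 nM in this assay and these two values lie within the scatter of each other. Compound 1 therefore stands on the weak side of both. Compound 4 (`C/C(=N\OCC(=O)N[C@H](C(=O)N[C@@H](CCCCN)C(=O)N1CCC[C@H]1C(=O)N[C@@H](CCCCN)C(=O)NCC(=O)O)[C@@H](C)O)c1ccc(NC(=O)c2cc(Br)ccc2O)cc1`) carries hydroxy in place of amino on a carbonyl carbon so that carbamoylmethyl becomes carboxymethyl while the rest of the structure stays the same. Among the measured compounds shown here, no measured pair shows this change, so the expectation rests on compound 1 alone. With compound 1 at > 200000 nM as a limit, no step beyond the scatter is expected in this assay in either direction, and a further limit is the likely report. The expected step is a number no higher from compound 1 to compound 4 (the limit leaves the size open) as estimated from that limit. Compound 4 is estimated at 200000 nM with an expected range of 90000 nM to 400000 nM for the coming measurement.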

Compound 4, half-maximal inhibitory concentration: > 200000 nM
Compound 4 ended at the assay's limit; the forecaster's own chance of this, stated with the estimate: 75%; the middle value lies on the limit itself.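

In this assay, among the compounds shown here, compound 1 and compound 4 both end at a limit and not a number, so no step between them can be read: the limit of > 200000 nM in this assay, at which 2 of the 4 values shown sit.

The compounds shown leave open whether hydroxy in place of amino on a carbonyl carbon shifts the read-out in a compound that gives a number.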